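The source may report more compounds than this note shows. Statements on the series, on what has been measured and on what is new or still open speak of the compounds shown alone.

Compound 1 `O=S(=O)(CC1=NCCS1)c1c(-c2ccc(Cl)cc2)noc1-c1ccc(Cl)cc1`: "not active" (no number reported)
Compound 2 `COc1ccc(-c2nn(-c3ccccc3)c(-c3ccc(C)cc3)c2S(=O)(=O)CC2=NCCO2)cc1`: 72.5%

In a functional assay, tested at 100 ug/mL (a higher number here means a stronger effect of the compound at the concentration tested, a lower number a weaker effect), compound 1 is reported only as "not active" (no number reported), with no single number behind it, so it stands without a measured value. Compound 2 differs from compound 1 in several places at once; in this assay compound 2 gives 72.5%. Compound 3 `O=S(=O)(CC1=NCCO1)c1c(-c2ccc(Cl)cc2)noc1-c1ccc(Cl)cc1` differs from compound 1 by a group of 5 heavy atoms (3 carbon, 1 nitrogen, 1 oxygen; one five-membered non-aromatic ring with 2 hetero atoms) in place of a group of 5 heavy atoms (3 carbon, 1 nitrogen, 1 sulfur; one five-membered non-aromatic ring with 2 hetero atoms), on a saturated chain carbon bound to a sulfonyl sulfur. Within the data shown here, no step between measured compounds of this kind is known, so the size of this one cannot be read from the data. The change is small, and no movement beyond the usual scatter is expected. Compound 3 is estimated at 15%, between 0% and 50%.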

Compound 3, a percentage reported as activity, at one concentration (the size of the read-out at that concentration, not a potency): "not active" (no number reported)
Compound 3: no number reported, and the estimate cannot be compared.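

In this assay compound 1 and compound 3 carry no number, so no step can be read between them. From the compounds shown here alone, how far exchanging the ring sulfur for oxygen can move the effect stays open. No supporting evidence bears on this result.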